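Cytotoxicity notes: aryl ether swap in the shared core

The source may report more compounds than this note shows. Statements on the series, on what has been measured and on what is new or still open speak of the compounds shown alone.

Compound 1 `O=C(CCCCC(=O)Nc1ncc(Cc2ccc(F)cc2)s1)Nc1ncc(Cc2ccc(F)cc2)s1` is the symmetric diamide of the set. In an ADME assay on HepG2 2.2.15 cells (Homo sapiens) for cytotoxicity (on this read-out lower numbers stand for higher toxicity in this test and higher numbers for lower toxicity in this test), compound 1 gives > 50000 nM, which is a limit of the assay and not a number. Compound 2 `Cc1cc(C(C)C)ccc1OC(c1ccc(Cl)cc1)c1cnc(NC(=O)OC(C)(C)C)s1` carries the 4-isopropyl-2-methylphenyl ether. In this assay compound 2 gives > 50000 nM, again a limit. Compound 3 `CC(C)(C)OC(=O)Nc1ncc(C(Oc2ccc(Br)cc2)c2ccc(Cl)cc2)s1` carries the 4-bromophenyl ether. In this assay compound 3 gives > 50000 nM, also a limit. Among the measured compounds shown here, the one measured step, a step that the two limits leave unreadable from compound 2 to compound 3, cannot be read, with both of its ends sitting at the limit (the limit of > 50000 nM in this assay, at which 3 of the 3 values shown sit). Compound 3 therefore has no numeric position within the set; it stands at the limit of > 50000 nM in this assay, at which 3 of the 3 values shown sit, shared by all three values shown.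

Compound 4 `CC(C)(C)OC(=O)Nc1ncc(C(Oc2ccc(F)c(Cl)c2)c2ccc(Cl)cc2)s1` differs from compound 3 by 3-chloro-4-fluorophenyl in place of 4-bromophenyl on an oxygen on a saturated carbon. For the measured compounds named here, only the step from compound 2 to compound 3 touches this position, and its size is not readable, so no size of step in this assay can be derived from the data. The expectation is accordingly no step beyond the scatter, with compound 4 expected to remain at the limit as well. The estimate for compound 4 is 60000 nM, within 30000 nM to 120000 nM. The step this estimate implies, a step that the limit leaves unreadable from compound 3 to compound 4, is expected to be nominal only.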

Compound 4, half-maximal cytotoxic concentration: > 50000 nM
Compound 4: no number, only a limit; the forecaster's own chance of this, stated with the estimate: 85%; the middle value is on the limit's open side.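

The steps from compound 3 to compound 4 and from compound 2 to compound 4 cannot be read in this assay, as all of these compounds sit at the same limit: the limit of > 50000 nM in this assay, at which 4 of the 4 values shown sit.

The compounds shown leave open how far any of them lies from that limit, and whether any aryl ether on the shared core gives a numeric read-out.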